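Sulfonamide variation in a thiourea vanilloid antagonist series

The compounds below may be only part of what the source reports. "The series", "measured", "known", "first", "only" and "open" are said of these compounds alone.

Measured compounds:
compound 1 `COc1cc(C/N=C(\S)NCc2ccc(C(C)(C)C)cc2)ccc1OS(C)(=O)=O` gives 300 nM
compound 2 `CCS(=O)(=O)Nc1ccc(C/N=C(\S)NCc2ccc(C(C)(C)C)cc2)cc1` gives 1300 nM

In a functional assay for antagonist activity at Vanilloid receptor (Rattus norvegicus) (a higher number here means a weaker inhibitor, a lower number a stronger inhibitor), compound 2 stands with the higher of the two numbers; its nearest neighbour is compound 1, whose lower number lies beyond the usual scatter. The two compounds differ in more than one place, so their gap is not assigned to a single change.

Compound 3 `CN(C)S(=O)(=O)Nc1ccc(C/N=C(\S)NCc2ccc(C(C)(C)C)cc2)cc1` is the next compound to go into this assay. The change from compound 2 is dimethylamino in place of ethyl on a sulfonyl sulfur. For the measured compounds named here, no pair of measured compounds shows this change, so there is no measured step to lean on. The expectation is a step of little size, in no certain direction, and none beyond the scatter, so that from compound 2 to compound 3 the number is estimated to move by a 1.2-fold higher number from compound 2 to compound 3 (0.06 log units; within the scatter). Compound 3 is therefore expected to give 1500 nM, with a range from 500 nM to 4500 nM.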

Compound 3, half-maximal inhibitory concentration: 14600 nM
The estimate for compound 3 lay 9.7-fold (0.99 log units) below the measured number; the whole stated range lies below it.
By their numbers in this assay, from the lowest: compound 1; then compound 2; then compound 3.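

In this assay the group on the sulfonyl sulfur proves to matter: with the sulfonamide nitrogen kept as the sulfur's other neighbour, dimethylamino in place of ethyl weakens inhibition sharply (an 11-fold higher number from compound 2 to compound 3 (1.05 log units; beyond the scatter)). For the compounds shown here, this is the first change that can be read at a single place, and it shows that the two groups are not interchangeable here, although each carries no ring, no net charge and no hydrogen-bond donor or acceptor by the computed count. No measured property is available to account for this step.

Going by these compounds, whether the loss follows the entering nitrogen or the two methyl branches stays open. An isopropyl or a methylamino group on the same sulfonyl sulfur would separate these two readings.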